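The source may report more compounds than this note shows. Statements on the series, on what has been measured and on what is new or still open speak of the compounds shown alone.

Among the compounds with values here, compound 2, `COc1cc(OC)c(C(=O)/C=C/c2ccccc2SC)c(OC)c1`, is the one member of this small set for which a number is in hand: in a functional assay on NCI-H727 cells (Homo sapiens), read by fluorescence and BrdU incorporation, with a stated time of 48 h, tested at 10 uM (on this read-out lower numbers stand for a stronger effect and higher numbers for a weaker effect at the one concentration tested), compound 2 gives 35%. Compound 1, `COc1cc(O)c(C(=O)/C=C/c2ccc(F)cc2)c(OC)c1`, belongs to the same family but in this assay compound 1 is recorded only as "not active" (no number reported), with no figure behind it, so compound 2 stands alone on the numbers shown and no ordering between the two can be drawn.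

The next compound, compound 3, `COc1cccc(/C=C/C(=O)c2c(OC)cc(OC)cc2OC)c1`, differs from compound 2 in a single spot: 3-methoxyphenyl in place of 2-(methylsulfanyl)phenyl on a double-bonded chain carbon bound to a double-bonded chain carbon. The carbonyl-linked chain and the rest of the shared core are untouched.

Within the data shown here, no pair of measured compounds shows what such a swap does on this read-out, so the size of the step has to be guessed. A modest shift toward a weaker effect is expected, a number 15 percentage points higher from compound 2 to compound 3 (beyond the scatter), a step close to the edge of the usual scatter rather than clearly beyond it, because compound 2 gives 35% and nothing in the set argues for a large departure from it. For compound 3 in this assay the expected activity is therefore 50%, with a range from 20% to 85%.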

Compound 3, a percentage reported as activity, at one concentration (the size of the read-out at that concentration, not a potency): 37%
Compound 3: middle estimate off by 13 percentage points, on the high side; measured number inside the range.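

In this assay, putting 3-methoxyphenyl in place of 2-(methylsulfanyl)phenyl on a double-bonded chain carbon bound to a double-bonded chain carbon gives a number 2 percentage points higher from compound 2 to compound 3 (within the scatter), so this one exchange leaves the read-out indistinguishable. Within the data shown here, this is the first direct comparison at this place, which the earlier compounds could not provide, and it shows that these two aromatic groups, each counted at 8 heavy atoms and 1 hydrogen-bond acceptor, can be exchanged here without a difference beyond the usual scatter at the one concentration tested. No measurement at hand accounts for this equivalence.

The pair alone cannot separate the effect of the sulfur-containing group from that of the oxygen-containing group, nor the effect of where each group sits on the phenyl ring, since 2-(methylsulfanyl)phenyl and 3-methoxyphenyl differ in both respects. It also leaves open whether the same tolerance would hold for a phenyl ring carrying an amine or a carboxylic acid at this place, or for a longer chain in place of the methoxy group.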